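The compounds below may be only part of what the source reports. "The series", "measured", "known", "first", "only" and "open" are said of these compounds alone.

For the measured compounds named here, in an ADME assay on microsomes from liver (Mus musculus) for metabolic stability, with a stated time of 10 min (on this read-out lower numbers stand for a less stable compound and higher numbers for a more stable compound), the series holds two numbers so far. Compound 1 (`C[C@]1(C(=O)N2CC[C@](c3ccc(C(F)(C(F)(F)F)C(F)(F)F)cc3)(S(=O)(=O)c3ccc(F)cc3)C2)CC[C@@H](C(=O)O)CC1`) gives 100%, and compound 3 (`CS(=O)(=O)C1CCC(C(=O)N2CC[C@](c3ccc(C(F)(C(F)(F)F)C(F)(F)F)cc3)(S(=O)(=O)c3ccc(F)cc3)C2)CC1`) gives 69%; "not determined" (no result reported) (2 entries). Compound 2 (`O=C(O)C12CCC(C(=O)N3CC[C@](c4ccc(C(F)(C(F)(F)F)C(F)(F)F)cc4)(S(=O)(=O)c4ccc(F)cc4)C3)(CC1)C2`) has no number to start from, its only entry being "not determined" (no result reported). Compound 4 (`O=C([C@H]1CC[C@H](CO)CC1)N1CC[C@](c2ccc(C(F)(C(F)(F)F)C(F)(F)F)cc2)(S(=O)(=O)c2ccc(F)cc2)C1`) is the next structure to be read. The structural change is a group of 8 heavy atoms (7 carbon, 1 oxygen; one six-membered non-aromatic ring of carbon only) in place of a group of 10 heavy atoms (8 carbon, 2 oxygen; 2 five-membered non-aromatic rings of carbon only), on a carbonyl carbon, and the group that enters is 4-(hydroxymethyl)cyclohexyl, on a carbonyl carbon. No step size can be taken from compound 2 itself. A moderate step toward a less stable reading than compound 1 at 100% is expected, ending near compound 3 at 69%; "not determined" (no result reported) (2 entries). Compound 4 is estimated at 65%, with an expected range of 35% to 90%.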

Compound 4, percent of the compound remaining: 63%
Compound 4: middle estimate off by 2 percentage points, on the high side; measured number inside the range.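

In this assay, for the compounds shown here, 4-(hydroxymethyl)cyclohexyl in place of 4-carboxy-1-methylcyclohexyl on a carbonyl carbon gives a number 37 percentage points lower from compound 1 to compound 4 (beyond the scatter), the first readable step at this place, showing that the reading responds to this group. Compound 2 has no number, and steps from it cannot be read. Compound 3 offers only one number for comparison with compound 4: the several entries of compound 3 in this assay, 69%; "not determined" (no result reported) (2 entries)

This change swaps the carboxylic acid and removes the methyl together, so their shares stay unseparated. Going by these compounds, a 4-carboxycyclohexyl group without the methyl, or an amine on the cyclohexane ring, remains open.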